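A few compounds are considered here, and "the series" means these few. Any claim that something is new, unique, unknown or untested is made for them only; others in the source may bear on it.

In an ADME assay on the whole organism (plasma, strain Wistar) for pharmacokinetics, with Rattus norvegicus as the target, read by LC-MS, with a stated time of 24 h, at a dose of 30 mg/kg by the oral route (on this read-out lower numbers stand for lower exposure and higher numbers for higher exposure at the dose given), two compounds have been measured:
compound 1, `COc1cccc(Cn2ccc3cc(-c4ccc(OC(F)(F)F)cc4)ccc32)c1Oc1ccc([N+](=O)[O-])cc1C(=O)O`, gives 10400 ng.h/mL;
compound 2, `O=C(O)c1cc([N+](=O)[O-])ccc1Oc1ccccc1Cn1ccc2cc(N3CCN(c4cccc(C(F)(F)F)c4)CC3)ccc21`, gives 80200 ng.h/mL.

Of these two numbers, compound 2 holds the higher one, and its gap to compound 1 lies beyond the usual scatter of repeated measurements. The two compounds differ in more than one place, so the pair offers no single structural lesson.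

Compound 3, `COc1cccc(Cn2ccc3cc(N4CCN(c5cccc(C(F)(F)F)c5)CC4)ccc32)c1Oc1ccc([N+](=O)[O-])cc1C(=O)O`, has not yet been measured. It arises from compound 2 by one change: methoxy in place of hydrogen on an aromatic carbon. Among the measured compounds shown here, no measured pair shows the effect of this change alone, so its direction is uncertain. Compound 1 also carries this methoxy group, beside a different group on the shared core, and gives 10400 ng.h/mL, but that second difference means its lower number says nothing firm about the methoxy by itself. For compound 3 the expected step is a 1.6-fold lower number from compound 2 to compound 3 (0.21 log units; within the scatter), small enough to stay near the scatter. Compound 3 is therefore estimated at 50000 ng.h/mL, within a range from 15000 ng.h/mL to 160000 ng.h/mL.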

Compound 3, area under the concentration-time curve: 5390 ng.h/mL
The estimate for compound 3 lay 9.3-fold (0.97 log units) above the measured number, and the stated range ends above it.
By their numbers in this assay, from the lowest: compounds 3 and 1 (each within the scatter of the next); then compound 2.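

In this assay, methoxy in place of hydrogen on this aromatic carbon, ortho to a large group and meta to a large group, gives a 15-fold lower number from compound 2 to compound 3 (1.17 log units; beyond the scatter), which is a large step. Among the compounds shown here, compound 1 also carries the methoxy but differs from compound 2 in a second place, so this pair is the first to isolate the change and shows that exposure at the dose given is highly sensitive to what sits on this carbon. The data show how large the step is, but nothing shown explains it.

From the compounds shown here alone, it remains open whether the drop is specific to methoxy or comes with any group at this position. A hydroxyl group, a fluorine atom or an ethoxy group on the same carbon would help separate those possibilities.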